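A few compounds are considered here, and "the series" means these few. Any claim that something is new, unique, unknown or untested is made for them only; others in the source may bear on it.

Within the data shown here, compound 1 `C=C(Br)C(=O)Nc1cccc(-c2cn3nc(-c4ccc(F)cc4)sc3n2)c1` holds the lowest of the two numbers measured so far in a functional assay on L1210 cells (Mus musculus) for inhibition, read by cell counting, with a stated time of 2 days (on this read-out lower numbers stand for stronger inhibition and higher numbers for weaker inhibition), where compound 1 gives 250 nM. Compound 2 `C=C(Br)C(=O)Nc1cccc(-c2cn3nc(Cc4cccc(OC)c4)sc3n2)c1` gives 2000 nM, a step of an 8.0-fold higher number from compound 1 to compound 2 (0.90 log units; beyond the scatter). Compound 3 `C=C(Br)C(=O)Nc1cccc(-c2cn3nc(-c4ccc(OCC)cc4)sc3n2)c1` differs from compound 1 by ethoxy in place of fluoro on an aromatic carbon. Among the measured compounds shown here, the one measured step exchanges an entire group on an aromatic carbon, so it bears only loosely on this smaller change. A modest weakening is expected in this assay, a 2.0-fold higher number from compound 1 to compound 3 (0.30 log units; within the scatter). Compound 3 is therefore estimated at 500 nM, with a range from 150 nM to 1700 nM.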

Compound 3, half-maximal inhibitory concentration: 790 nM
Compound 3: the middle estimate sits 1.6-fold (0.20 log units) below what was measured, within the range that was stated.
By their numbers in this assay, from the lowest: compound 1; then compound 3; then compound 2.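

In this assay ethoxy in place of fluoro, para to a large group, gives a 3.2-fold higher number from compound 1 to compound 3 (0.50 log units; beyond the scatter) and so shows that this position tolerates the larger group at a modest cost. Replacing 3-methoxybenzyl with 4-ethoxyphenyl gives a 2.5-fold lower number from compound 2 to compound 3 (0.40 log units; beyond the scatter) and so shows that an ethoxy-bearing phenyl still keeps a lower number than the benzyl group. Going by these compounds, whether a longer chain such as butoxy, an amine or a carboxylic acid would fit this same place remains open. No measurement available here explains why the number rises with ethoxy.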